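Replacing a Chlorinated Amine Chain with a Hydroxy-Piperidinyl Chain

A few compounds are considered here, and "the series" means these few. Any claim that something is new, unique, unknown or untested is made for them only; others in the source may bear on it.

Measured so far:
compound 1, `CCCCCCCCCCc1ccc(-c2noc(CC3CNC3)n2)cc1`, 63% in an assay on HeLa cells for inhibition of sphingosine-1-phosphate transporter SPNS2 (Mus musculus), read by LC-MS, tested at 2 uM; a higher number here means more inhibition at the concentration tested (going by the name of the read-out), a lower number less inhibition
compound 2, `CCCCCCCCCCc1ccc(-c2noc(C(Cl)CCN)n2)cc1`, 5%

Compound 2 stands lowest of the two numbers; compound 1 lies a number 58 percentage points lower from compound 1 to compound 2 (beyond the scatter). Compound 3, `CCCCCCCCCCc1ccc(-c2noc(CC(O)CN3CCCCC3)n2)cc1`, has not been measured. It differs from compound 2 by a group of 10 heavy atoms (8 carbon, 1 nitrogen, 1 oxygen; one six-membered non-aromatic ring with 1 hetero atom) in place of a group of 5 heavy atoms (3 carbon, 1 nitrogen, 1 chlorine; no ring), on an aromatic carbon. For the measured compounds named here, the only measured step bearing on this change is the one from compound 1 to compound 2, where the group with a ring amine was exchanged for a chain without a ring and inhibition fell by a large margin. Compound 3 brings a ring amine back, so a rise is expected: a number 35 percentage points higher from compound 2 to compound 3 (beyond the scatter). Compound 3 is therefore estimated at 40%, with a range from 10% to 75%.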

Compound 3, a percentage reported as inhibition, at one concentration (the size of the read-out at that concentration, not a potency): 2%
The estimate for compound 3 lay 38 percentage points above the measured number, and the stated range ends above it.
By their numbers in this assay, from the lowest: compounds 3 and 2 (each within the scatter of the next); then compound 1.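

In this assay, bringing a ring amine back to this position does not by itself restore inhibition: the change reads a number 3 percentage points lower from compound 2 to compound 3 (within the scatter) and leaves 2-hydroxy-3-(piperidin-1-yl)propyl no different from the chlorinated chain. The piperidine compound also reads a number 61 percentage points lower from compound 1 to compound 3 (beyond the scatter) and so does not stand in for the azetidin-3-yl group. No measurement given here explains this. On these data alone, the hydroxyl and piperidine arrive together, so their separate contributions remain open. A pyrrolidine on the same chain without the hydroxyl would help separate ring size from the hydroxyl.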